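The source may hold more compounds than are shown below. What is called first, only, known or untested is meant among the compounds shown, and "the series" means these compounds.

In a physicochemical assay for solubility, in phosphate buffer, at pH 7.4 (a lower number here means a less soluble compound, a higher number a more soluble compound), compound 3 `c1ccc2nc(N3CC(Oc4nccnc4N4CCCCC4)C3)ccc2c1` gives < 1000 nM, which is a limit of the assay and not a number. Compound 1 `OCCC1CCN(c2nccnc2OC2CN(c3ccc4ccccc4n3)C2)CC1` gives 84000 nM and compound 2 `OC1CCN(c2nccnc2OC2CN(c3ccc4ccccc4n3)C2)CC1` gives 99000 nM. The step of a 1.2-fold higher number from compound 1 to compound 2 (0.07 log units; within the scatter) lies within the scatter, so 2-hydroxyethyl and hydroxy cannot be told apart here.

Compound 4 `CN(C)C1CCN(c2nccnc2OC2CN(c3ccc4ccccc4n3)C2)CC1` has dimethylamino in place of hydrogen on a saturated ring carbon. It has not yet been measured.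

For the measured compounds named here, two measured steps bear on this change: an at least 84-fold lower number from compound 1 to compound 3 (1.92 log units; beyond the scatter) and an at least 99-fold lower number from compound 2 to compound 3 (1.99 log units; beyond the scatter). Both are large and beyond the scatter, and both run towards hydrogen, so the change to compound 4 runs the opposite way. The comparison is only an analogy, as neither measured group is dimethylamino.

The expected step is large and towards a higher number, an at least 70-fold higher number from compound 3 to compound 4 (1.84 log units; beyond the scatter). For compound 4 the estimated value in this assay is 70000 nM, with an expected range of 15000 nM to 200000 nM.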

Compound 4, solubility: 500000 nM
The estimate for compound 4 lay 7.1-fold (0.85 log units) below the measured number; the whole stated range lies below it.
By their numbers in this assay, from the lowest: compounds 1 and 2 (each within the scatter of the next); then compound 4. At a limit, below all of these: compound 3.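

Among the groups shown on this saturated ring carbon, dimethylamino alone stands apart from the others in this assay, with a 5.1-fold higher number from compound 2 to compound 4 (0.70 log units; beyond the scatter) and a 6.0-fold higher number from compound 1 to compound 4 (0.77 log units; beyond the scatter), both modest and beyond the scatter. The position therefore distinguishes among groups that replace hydrogen, and does not merely separate hydrogen from everything else, while the largest change remains an at least 500-fold higher number from compound 3 to compound 4 (2.69 log units; beyond the scatter). The size of that last step is only a bound, as compound 3 stands at a limit: the limit of < 1000 nM in this assay, at which 1 of the 4 values shown sits.

From the compounds shown here alone, it remains open whether this result extends to amines generally or belongs to dimethylamino alone, a question that a primary amine or a carboxylic acid on the same carbon would help settle. Also open, going by these compounds, is whether a longer chain ending in dimethylamino would match compound 4.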